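Dropping a Methoxy from a Benzylamide Inhibitor

A few compounds are considered here, and "the series" means these few. Any claim that something is new, unique, unknown or untested is made for them only; others in the source may bear on it.

Compound 1 `COc1ccc(CNC(=O)c2nc(-c3ccc(F)cc3)n(CC[C@@H](O)C[C@@H](O)CC(=O)O)c2C2CC2)cc1` and compound 2 `Cc1ccc(CNC(=O)c2nn(-c3ccc(F)cc3)c(CC[C@@H](O)C[C@@H](O)CC(=O)O)c2C(C)C)cc1` were both tested in an assay on microsomes from liver for inhibition of 3-hydroxy-3-methylglutaryl-coenzyme A reductase (Rattus norvegicus), read by scintillation counting, with stated times of 0.5 h and 0.75 h; on this read-out lower numbers stand for stronger inhibition and higher numbers for weaker inhibition. Compound 1 gives 1.2 nM, and compound 2 gives 1 nM; these two values fall within the usual scatter of repeated measurements, so neither stands apart from the other. Compound 3 `O=C(O)C[C@H](O)C[C@H](O)CCn1c(-c2ccc(F)cc2)nc(C(=O)NCc2ccccc2)c1C1CC1` is compound 1 with hydrogen in place of methoxy on an aromatic carbon, which reads as 4-methoxybenzyl to benzyl on the amide. Within the data shown here, no measured pair shows this exact change, so its size cannot be read from the data. A small loss, or none beyond the scatter, is expected: the change is estimated as a 1.7-fold higher number from compound 1 to compound 3 (0.22 log units; within the scatter). Compound 3 is therefore expected to give about 2 nM, within 0.7 nM to 6 nM.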

Compound 3, half-maximal inhibitory concentration: 1.4 nM
Estimate against measurement, compound 3: 1.4-fold (0.15 log units) above; low and high end bracket the measured number.
By their numbers in this assay, from the lowest: compounds 2, 1 and 3 (each within the scatter of the next).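

Going from 4-methoxybenzyl to benzyl on the amide gives a 1.2-fold higher number from compound 1 to compound 3 (0.07 log units; within the scatter) and so the two compounds cannot be told apart. On this core, the methoxy is therefore not needed for inhibition at the level seen with compound 1, and a plain phenyl ring serves as well. No other measurement here offers an explanation for this result. Still open, as far as these compounds go, is whether a larger or charged group in the same place, such as an amine or a carboxylic acid, would be tolerated as well. From the compounds shown here alone, a fluorine or a hydroxyl there remains an equally open case.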